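Pyridin-3-yl to Pyridin-4-yl on Two Amide Linkers

The source may hold more compounds than are shown below. What is called first, only, known or untested is meant among the compounds shown, and "the series" means these compounds.

Compound 1 `Cc1cc(C)c2cc(C#N)c(NCCNC(=O)c3cccnc3)nc2c1` and compound 2 `Cc1cc(C)c2cc(C#N)c(NCCNC(=O)c3ccncc3)nc2c1` differ only by pyridin-4-yl in place of pyridin-3-yl on a carbonyl carbon. In an in vitro assay on FRT cells with Cystic fibrosis transmembrane conductance regulator variant F508del (Homo sapiens) as the target, read by fluorescence, with a stated time of 24 h, at 37 degrees C, in the presence of a further agent that is not named here (a lower number here means that less compound is needed, a higher number that more compound is needed for the effect), compound 1 gives 2700 nM. In this assay compound 2 gives 7300 nM. The step of a 2.7-fold higher number from compound 1 to compound 2 (0.43 log units; beyond the scatter) is beyond the scatter, so the swap costs something on this open-chain amide. Compound 3 `Cc1cc(C)c2cc(C#N)c(N3CCN(C(=O)c4cccnc4)CC3)nc2c1` carries a different core, and the difference between the two cores is not broken down here. In this assay compound 3 gives "not active" (no number reported), with no number reported. Compound 4 `Cc1cc(C)c2cc(C#N)c(N3CCN(C(=O)c4ccncc4)CC3)nc2c1` differs from compound 3 by pyridin-4-yl in place of pyridin-3-yl on a carbonyl carbon. Here the carbonyl carbon sits on an amide-type nitrogen in a ring, whereas in compound 1 it sits on an amide-type nitrogen, so this is the same kind of change rather than the same one. The account from compound 1 to compound 2 suggests the swap does not help, and compound 3 already gives no number, so compound 4 is expected to fall at the weak end as well, estimated at 30000 nM within 8000 nM to 100000 nM, most likely again reported only as inactive.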

Compound 4, half-maximal effective concentration: "not active" (no number reported)
Compound 4: no number reported, so the estimate cannot be set against anything.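

Compound 3 and compound 4 are both reported without a number, so no step can be read between them. Nothing available here accounts for this result. As far as these compounds go, what remains open is whether pyridin-4-yl in place of pyridin-3-yl on this amide-type nitrogen in a ring would match a 2.7-fold higher number from compound 1 to compound 2 (0.43 log units; beyond the scatter) on the open-chain amide.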